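The source may report more compounds than this note shows. Statements on the series, on what has been measured and on what is new or still open speak of the compounds shown alone.

Measured so far:
- compound 1, `O=C(Nc1nc(-c2ccc(Cl)cc2)cs1)c1cc([N+](=O)[O-])ccc1Cl`, in an ADME assay for permeability, using PAMPA, at pH 7.4 (a lower number here means that the compound crosses the layer more slowly, a higher number that the compound crosses the layer faster), gives 3 10^-6 cm/s.
- compound 2, `Cc1ccc(-c2nc3ccccc3o2)cc1NC(=O)c1cc([N+](=O)[O-])ccc1Cl`, in this assay gives "below limit of detection" (no number reported).

In this assay compound 2 gives no number: its permeability value reads "below limit of detection" (no number reported). Compound 1 gives a measured number, 3 10^-6 cm/s, so of the two only compound 1 places itself on the scale.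

Compound 3, `COc1ccc(-c2nc3ccccc3o2)cc1NC(=O)c1cc([N+](=O)[O-])ccc1Cl`, is not yet measured. It differs from compound 2 in one place: methoxy in place of methyl on an aromatic carbon.

For the measured compounds named here, no comparable step between measured compounds exists, so the size of this change in this assay can only be guessed. The expectation is a small step, if any, within the scatter, with no clear direction, and compound 3 may well stay at the limit of detection as compound 2 does. For compound 3 the estimated permeability is 0.5 10^-6 cm/s, with a range from 0.1 10^-6 cm/s to 3 10^-6 cm/s.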

Compound 3, apparent permeability in the ADME assay: 274 10^-6 cm/s
Compound 3: middle estimate off by 550-fold (2.74 log units), on the low side; the measured number lies above the stated range.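

For the compounds shown here, in the ADME assay compound 2 gives no number, so no step from compound 2 to compound 3 can be read there. In a physicochemical assay for solubility, read by spectrophotometry, in phosphate buffer, measured as kinetic solubility, with a stated time of 18 h, at pH 7.4 (a lower number here means a less soluble compound, a higher number a more soluble compound), compound 2 gives 310 nM and compound 3 gives 90 nM. As far as these compounds go, how much methoxy in place of methyl changes permeability stays open.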